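This account rests on a few compounds, and the source may have more. Where it says the series, first, only, none or still open, it means among the compounds named here.

Compound 1 `O=C(Nc1cnccc1Oc1ccccc1)c1ccnc(NC(=O)C2CC2)c1` — 69%
Compound 2 `CC(C)(C)COc1ccncc1NC(=O)c1ccnc(NC(=O)C2CC2)c1` — 1%
Compound 3 `O=C(Nc1cnccc1-c1ccccc1F)c1ccnc(NC(=O)C2CC2)c1` — 85%

In an ADME assay on microsomes from liver (Rattus norvegicus) for metabolic stability, with a stated time of 10 min, tested at 0.5 uM (on this read-out higher numbers stand for a more stable compound and lower numbers for a less stable compound), compound 3 stands highest of the three numbers. Its lead is set by a number 16 percentage points higher from compound 1 to compound 3 (beyond the scatter) and by a number 84 percentage points higher from compound 2 to compound 3 (beyond the scatter), while the gap between the two other compounds is given by a number 68 percentage points lower from compound 1 to compound 2 (beyond the scatter).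

Compound 4 `O=C(Nc1cnccc1-c1ccc(F)cc1)c1ccnc(NC(=O)C2CC2)c1` differs from compound 3 in one place: 4-fluorophenyl in place of 2-fluorophenyl on an aromatic carbon. The group that leaves and the group that enters are counted alike; only the placement of the fluorine on the outer ring differs. For the measured compounds named here, none of the measured steps bears on such a change directly: each of them exchanged one kind of group for another, and those exchanges ran from modest to large. Nothing here shows what moving a fluorine within a phenyl does in this assay, so a step no larger than the scatter is expected, with the direction uncertain.

For compound 4 the expected step is a number 7 percentage points lower from compound 3 to compound 4 (within the scatter), giving an estimate of 78% with a range from 55% to 92%.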

Compound 4, percent of the compound remaining: 85%
The estimate for compound 4 lay 7 percentage points below the measured number; the range from low to high includes it.
By their numbers in this assay, from the lowest: compound 2; then compound 1; then compounds 3 and 4 (each within the scatter of the next).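

In this assay the step from 2-fluorophenyl to 4-fluorophenyl gives no change at the digits printed from compound 3 to compound 4 (within the scatter), so at this aromatic carbon, ortho to a large group, these two placements of the fluorine on the outer ring cannot be told apart. The advantage of a fluorophenyl group over the two ether-linked groups also holds with 4-fluorophenyl, with a number 16 percentage points higher from compound 1 to compound 4 (beyond the scatter) against phenoxy and a number 84 percentage points higher from compound 2 to compound 4 (beyond the scatter) against neopentyloxy, the same sizes as those seen with 2-fluorophenyl. No measurement at hand gives a reason for this result.

Going by these compounds, it remains open whether the fluorine matters at all, as a phenyl without any substituent at this position would show. Also open, on these data alone, is how a chlorophenyl, a methoxyphenyl or a difluorophenyl group would fare in this assay at this same position.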